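From Ethyl to Propyl in a Cell Cytotoxicity Comparison

The source may hold more compounds than are shown below. What is called first, only, known or untested is meant among the compounds shown, and "the series" means these compounds.

In a functional assay on MCF7 cells (Homo sapiens) for cytotoxicity, read by MTT assay, with a stated time of 72 h (a lower number here means a stronger inhibitor, a higher number a weaker inhibitor), compound 1 (`S=C=NCCCCSCc1ccccc1`) reads 38300 nM on measurement, while compound 2 (`CC[S+]([O-])CCCCN=C=S`) reads 8260 nM and so holds the lower of the two numbers. That makes compound 2 the stronger inhibitor of the pair, and the gap between them lies beyond the usual scatter. The two structures differ in more than one place, so the gap cannot be tied to any single change.

Compound 3 (`CCC[S+]([O-])CCCCN=C=S`) has not yet been measured. It differs from compound 2 by methyl in place of hydrogen on a saturated chain carbon, two bonds along the chain from a sulfur (in words, methyl in place of hydrogen on a saturated chain carbon, two bonds along the chain from a sulfur), so that ethyl becomes propyl. Among the measured compounds shown here, no measured pair shows this kind of change in this assay and the expectation therefore starts from compound 2 with its 8260 nM as the reference. No step beyond the scatter is expected, and any direction is only tentative. The estimated change is a 1.1-fold lower number from compound 2 to compound 3 (0.04 log units; within the scatter) and it is expected to stay within the scatter. For compound 3 the expected value is 7500 nM with an estimated range of 3500 nM to 16000 nM in this measurement.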

Compound 3, half-maximal inhibitory concentration: 5960 nM
Compound 3: middle estimate off by 1.3-fold (0.10 log units), on the high side, and the stated range covers the measured number.
By their numbers in this assay, from the lowest: compounds 3 and 2 (each within the scatter of the next); then compound 1.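

In this assay, among the compounds shown here, the change of ethyl to propyl gives the first comparison here that differs in only one place, and the step of a 1.4-fold lower number from compound 2 to compound 3 (0.14 log units; within the scatter) stays within the scatter. The earlier pair differed in more than one place and could say nothing about this position, whereas this result shows that methyl in place of hydrogen on a saturated chain carbon, two bonds along the chain from a sulfur, leaves compound 2 and compound 3 indistinguishable by this read-out. No measured evidence accompanies this step, so the result gives no explanation of it.

The compounds shown leave open whether the same flat reading would hold for a longer chain such as butyl, or whether a branched chain such as isopropyl would give a step beyond the scatter at this place. They also leave open what a hydroxyl group or a carboxylic acid at the end of this chain would do, since a single step between ethyl and propyl cannot describe the wider reach of this position.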